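This account rests on a few compounds, and the source may have more. Where it says the series, first, only, none or still open, it means among the compounds named here.

In a functional assay on MCF7 cells (Homo sapiens) for antiproliferative activity, read by MTT assay, with a stated time of 72 h (a higher number here means a weaker inhibitor, a lower number a stronger inhibitor), compound 1 `Cc1cc(NCCN2CCN(C)CC2)nc2ccc(NC(=O)c3ccc(Cl)c(Cl)c3)cc12` gives 1700 nM, while compound 3 `Cc1cc(N(C)C)nc2ccc(NC(=O)c3ccc(Cl)c(Cl)c3)cc12` gives 33300 nM, so that a 20-fold higher number from compound 1 to compound 3 (1.29 log units; beyond the scatter). Compound 2 `CCc1ccccc1C(=O)Nc1ccc2nc(N3CCN(CC)CC3)cc(C)c2c1` gives 15800 nM in this assay, the second highest of the three numbers; its nearest neighbour is compound 3 and its furthest is compound 1. Compound 4 `CCN1CCN(c2cc(C)c3cc(NC(=O)c4ccco4)ccc3n2)CC1` is not yet measured. It differs from compound 2 only at the amide end of the shared core: furan-2-yl in place of 2-ethylphenyl on a carbonyl carbon. Within the data shown here, the one measured step, from compound 1 to compound 3, changes the other end of the core and tells nothing about a swap on the carbonyl carbon. Among the measured compounds shown here, with no measured step bearing on this change, the step of a 1.0-fold higher number from compound 2 to compound 4 (0.01 log units; within the scatter) is expected, in this assay, to stay within the usual scatter. Compound 4 is therefore estimated at 16000 nM, within 5000 nM to 50000 nM.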

Compound 4, half-maximal inhibitory concentration: 41200 nM
Compound 4: middle estimate off by 2.6-fold (0.41 log units), on the low side; measured number inside the range.
By their numbers in this assay, from the lowest: compound 1; then compound 2; then compounds 3 and 4 (each within the scatter of the next).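

The amide end of the shared core is not neutral in this assay: swapping the 2-ethylphenyl for furan-2-yl on this carbonyl carbon gives a 2.6-fold higher number from compound 2 to compound 4 (0.42 log units; beyond the scatter), a modest step but beyond the scatter. Among these compounds, the earlier step changed only the other end of the core, so this is the first reading at this position. Nothing measured here accounts for the shift. The swap removes the ethyl group, shrinks the ring to five members and brings in a ring oxygen, and these three changes remain unseparated. Phenyl or thiophen-2-yl on the same carbonyl carbon would help to pull them apart.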